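The compounds below may be only part of what the source reports. "The series", "measured", "known", "first", "only" and "open" are said of these compounds alone.

Measured in a functional assay on HCT-116 cells (Homo sapiens) for antiproliferative activity, read by sulforhodamine B assay, with a stated time of 72 h; a lower number here means a stronger inhibitor, a higher number a weaker inhibitor:
- compound 1 `CCCCS(=O)(=O)Nc1cc(-c2ccc3ncnc(NCCN(C)C)c3c2)cnc1OC`: 160 nM
- compound 2 `COc1ncc(-c2ccc3ncnc(NCc4ccncc4)c3c2)cc1NS(=O)(=O)c1ccc(F)cc1F`: 17600 nM

Of these two, compound 2 has the higher number at 17600 nM, and compound 1 stands at 160 nM. This gap lies beyond the scatter. For the measured compounds named here, the two compounds differ in more than one place, so the gap cannot be assigned to either change, and no single-change step has been measured.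

Next in the series is compound 3 `COc1ncc(-c2ccc3ncnc(NCCN(C)C)c3c2)cc1NS(=O)(=O)c1ccc(F)cc1F`, not yet measured. It keeps the sulfonamide of compound 2 and differs from it as follows: (dimethylamino)methyl in place of pyridin-4-yl on a saturated chain carbon bound to a nitrogen on an aromatic ring. Cut one bond further out, this reads (pyridin-4-yl)methyl to 2-(dimethylamino)ethyl, the chain also carried by compound 1.

In this assay, a lower number beyond the scatter is expected. This expectation rests on compound 1, which carries that chain and reads 160 nM, although its sulfonamide differs, so the size remains uncertain. The expected change is a 44-fold lower number from compound 2 to compound 3 (1.64 log units; beyond the scatter). For compound 3 the estimated value is 400 nM, with an expected range of 60 nM to 3000 nM.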

Compound 3, half-maximal inhibitory concentration: 1440 nM
For compound 3 the middle estimate is 3.6-fold (0.56 log units) below the measured one; the measured number falls inside the stated range.
By their numbers in this assay, from the lowest: compound 1; then compound 3; then compound 2.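

In this assay, with the 2,4-difluorophenyl sulfonamide held fixed, (dimethylamino)methyl in place of pyridin-4-yl on a saturated chain carbon bound to a nitrogen on an aromatic ring gives a 12-fold lower number from compound 2 to compound 3 (1.09 log units; beyond the scatter), so this position alone moves the number beyond the scatter, which the earlier pair, differing in more than one place, could not show. With the 2-(dimethylamino)ethyl chain held fixed, 2,4-difluorophenyl in place of butyl on a sulfonyl sulfur gives a 9.0-fold higher number from compound 1 to compound 3 (0.95 log units; beyond the scatter), so the sulfonyl substituent also matters and the original gap cannot be laid on the chain alone. Nothing measured here accounts for either step.

Still open, going by these compounds, is whether the chain step keeps its size with butyl on the sulfonyl sulfur, since both steps have been read only once and each against a single partner. Also open, on these data alone, is how this position reads with a longer chain ending in dimethylamino or with a morpholine in place of the dimethylamino group, and how the sulfonyl position reads with an unsubstituted phenyl.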